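Ethynyl in place of vinyl: working notes on the series

The source may report more compounds than this note shows. Statements on the series, on what has been measured and on what is new or still open speak of the compounds shown alone.

Going by the values given here, in an ADME assay on MDCK cells (Canis lupus familiaris) for cytotoxicity, read by CellTiter-Glo, with a stated time of 10 min (on this read-out lower numbers stand for higher toxicity in this test and higher numbers for lower toxicity in this test), compound 2 (`C=Cc1c([C@@H]2O[C@H](CO)[C@@H](O)[C@H]2O)ccnc1C(N)=O`) gives 152000 nM and stands highest of the two numbers so far, with compound 1 (`NC(=O)c1nccc([C@@H]2O[C@H](CO)[C@@H](O)[C@H]2O)c1O`) at 2000 nM on the low side. Compound 3 (`C#Cc1c([C@@H]2O[C@H](CO)[C@@H](O)[C@H]2O)ccnc1C(N)=O`) carries ethynyl in place of vinyl on an aromatic carbon. Among the compounds with values here, the one measured step that bears on this change is large and beyond the scatter (a 76-fold higher number from compound 1 to compound 2 (1.88 log units; beyond the scatter)), with vinyl in place of hydroxy on an aromatic carbon. Within the data shown here, that step concerns another pair of groups, so it sets no size for the new change and shows only that the number can move far. The expected step (a 1.7-fold lower number from compound 2 to compound 3 (0.23 log units; within the scatter)) is small, toward a lower number in this assay, and possibly not beyond the scatter. For compound 3 the expected value is 90000 nM (estimated range 20000 nM to 250000 nM).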

Compound 3, half-maximal cytotoxic concentration: 98000 nM
For compound 3 the middle estimate is 1.1-fold (0.04 log units) below the measured one, within the range that was stated.
By their numbers in this assay, from the lowest: compound 1; then compounds 3 and 2 (each within the scatter of the next).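

In this assay, ethynyl in place of vinyl on this aromatic carbon gives a 1.6-fold lower number from compound 2 to compound 3 (0.19 log units; within the scatter), so the two groups cannot be told apart here. Ethynyl in place of hydroxy at the same carbon gives a 49-fold higher number from compound 1 to compound 3 (1.69 log units; beyond the scatter), so the large step seen with vinyl is not unique to vinyl; among these three compounds, only hydroxy goes with the low number. No measurement at hand bears on the reason for these numbers.

On these data alone, whether an amine or a methoxy group at this place would stand with hydroxy at the low number or with vinyl and ethynyl at the high numbers remains open. So does the outcome with a longer chain, such as propynyl, on this carbon.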